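The source may hold more compounds than are shown below. What is called first, only, known or untested is meant among the compounds shown, and "the series" means these compounds.

Compound 1 `COc1ccc(C2=C(c3ccc(SC)cc3)CC3CCCN3C2=O)cc1O`: 6000 nM
Compound 2 `CSc1ccc(C2=C(c3ccc(F)c(F)c3)C(=O)N3CCCC3C2)cc1`: 500 nM
Compound 3 `CSc1ccc(C2=C(c3ccc(C)cc3)C(=O)N3CCCC3C2)cc1`: 600 nM

These values come from a functional assay on DU-145 cells (Homo sapiens) for cytotoxicity; a lower number here means a stronger inhibitor of growth, a higher number a weaker inhibitor of growth. Compound 3 stands level with compound 2 and well under compound 1. Compound 4 `CSc1ccc(C2=C(c3ccc(F)cc3)C(=O)N3CCCC3C2)cc1` has not been measured. It differs from compound 3 by one swap: fluoro in place of methyl on an aromatic carbon. The closest evidence is a 1.2-fold higher number from compound 2 to compound 3 (0.08 log units; within the scatter), which also exchanges a fluorinated ring for 4-methylphenyl. The large steps, a 12-fold lower number from compound 1 to compound 2 (1.08 log units; beyond the scatter) and a 10-fold lower number from compound 1 to compound 3 (1.00 log units; beyond the scatter), both start from the 3-hydroxy-4-methoxyphenyl group, which compound 4 lacks. The expected result is therefore no real shift, an estimated 1.1-fold lower number from compound 3 to compound 4 (0.04 log units; within the scatter). For compound 4 the expected value is 550 nM, with an estimated range of 250 nM to 1200 nM.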

Compound 4, concentration for 50% growth inhibition: 500 nM
The estimate for compound 4 lay 1.1-fold (0.04 log units) above the measured number, and the stated range covers the measured number.
By their numbers in this assay, from the lowest: compounds 2, 4 and 3 (each within the scatter of the next); then compound 1.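

In this assay, fluoro in place of methyl on this aromatic carbon gives a 1.2-fold lower number from compound 3 to compound 4 (0.08 log units; within the scatter) and hydrogen in place of the second fluoro gives no change at the digits printed from compound 2 to compound 4 (within the scatter) so these three rings cannot be told apart. The 3-hydroxy-4-methoxyphenyl group remains the outlier, with a 12-fold lower number from compound 1 to compound 4 (1.08 log units; beyond the scatter) on moving to 4-fluorophenyl. No measurement shown here accounts for this pattern.

As far as these compounds go, whether an amine or a carboxylic acid in place of the fluoro would also leave the number unmoved stays open. So does whether the hydroxy or the methoxy of compound 1 alone would produce the large step.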